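A few compounds are considered here, and "the series" means these few. Any claim that something is new, unique, unknown or untested is made for them only; others in the source may bear on it.

Values in a functional assay on MCF7 cells (Homo sapiens) for antiproliferative activity, read by MTT assay, with a stated time of 24 h; on this read-out higher numbers stand for weaker inhibition and lower numbers for stronger inhibition:
- compound 1 `CCn1c(C(=O)N[C@@H](C)C(=O)OC)ccc1C(CC)(CC)c1ccc(OCS(=O)(=O)c2ccccc2)c(C)c1`: 43700 nM
- compound 2 `CCn1c(C(=O)NCCC(=O)OC)ccc1C(CC)(CC)c1ccc(OCS(=O)(=O)c2ccccc2)c(C)c1`: > 50000 nM (a limit, not a number)
- compound 3 `CCn1c(C(=O)N[C@H](CO)CCO)ccc1C(CC)(CC)c1ccc(OCS(=O)(=O)c2ccccc2)c(C)c1`: 28500 nM

Compound 3, at 28500 nM, lies within the scatter of compound 1, at 43700 nM. The only other result is the limit of compound 2, > 50000 nM.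

The next change leads to compound 4 `CCn1c(C(=O)NC2(C(=O)O)CC2)ccc1C(CC)(CC)c1ccc(OCS(=O)(=O)c2ccccc2)c(C)c1`: 1-carboxycyclopropyl in place of 3-hydroxy-1-(hydroxymethyl)propyl on an amide-type nitrogen.

Going by the values given here, three measured steps bear on this, all made at the same nitrogen: an at least 1.1-fold higher number from compound 1 to compound 2 (0.05 log units; that floor lies within the scatter), a 1.5-fold lower number from compound 1 to compound 3 (0.19 log units; within the scatter) and an at least 1.7-fold lower number from compound 2 to compound 3 (0.24 log units; that floor lies within the scatter). Each lies within the scatter, and the two involving compound 2 are only floors. Among the compounds with values here, no measured compound carries the entering group, so these steps are indirect guidance. No step beyond the scatter is therefore expected in this assay, and a result at the limit remains possible.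

The expected change is a 1.3-fold higher number from compound 3 to compound 4 (0.12 log units; within the scatter).

For compound 4 the estimate is 38000 nM, with an expected range of 15000 nM to 70000 nM.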

Compound 4, half-maximal inhibitory concentration: 41200 nM
For compound 4 the middle estimate is 1.1-fold (0.04 log units) below the measured one; the measured number falls inside the stated range.
By their numbers in this assay, from the lowest: compounds 3, 4 and 1 (each within the scatter of the next). At a limit, above all of these: compound 2.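

In this assay, 1-carboxycyclopropyl on the amide-type nitrogen brings a three-membered ring and a free carboxylic acid to this position, yet the number barely shifts: a 1.4-fold higher number from compound 3 to compound 4 (0.16 log units; within the scatter), and a 1.1-fold lower number from compound 1 to compound 4 (0.03 log units; within the scatter). The reading against the remaining ester is only a floor, an at least 1.2-fold lower number from compound 2 to compound 4 (0.08 log units; that floor lies within the scatter), so even this different kind of group produces no step beyond the scatter at this nitrogen. Compound 2 stands at a limit, not a number: the limit of > 50000 nM in this assay, at which 1 of the 4 values shown sits.

Open, as far as these compounds go, is whether an amine or a longer alkyl chain on this nitrogen would give a step beyond the scatter. Also open, from the compounds shown here alone, is how the three-membered ring and the carboxylic acid count separately, as they enter together in compound 4.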